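A few compounds are considered here, and "the series" means these few. Any claim that something is new, unique, unknown or untested is made for them only; others in the source may bear on it.

In a functional assay on HepG2 cells (Homo sapiens) for antiproliferative activity, read by MTT assay, with a stated time of 48 h (a higher number here means a weaker inhibitor, a lower number a stronger inhibitor), compound 1 `C#CCCOC(=O)c1ccc(C(CC)(CC)c2ccc(OCCC(O)(CC)CC)c(C)c2)n1CC` gives > 50000 nM as a limit of the assay and not a number. Compound 1 stands at the limit of > 50000 nM in this assay, at which 1 of the 2 values shown sits, as the series now reads. Among the measured compounds shown here, compound 2 `CCn1c(C(=O)NC(CC(=O)O)C(=O)OC)ccc1C(CC)(CC)c1ccc(OCCC(O)(CC)CC)c(C)c1` at 10700 nM holds the only actual number so far. For the measured compounds named here, the one measured step is an at least 4.6-fold lower number from compound 1 to compound 2 (0.66 log units; beyond the scatter) on a carbonyl carbon.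

Compound 3 `CCC(C)C(CO)NC(=O)c1ccc(C(CC)(CC)c2ccc(OCCC(O)(CC)CC)c(C)c2)n1CC` differs from compound 2 on an amide-type nitrogen: a group of 7 heavy atoms (6 carbon, 1 oxygen; no ring) in place of a group of 9 heavy atoms (5 carbon, 4 oxygen; no ring), on an amide-type nitrogen with 1-(hydroxymethyl)-2-methylbutyl as the entering group. Going by the values given here, no step at this place has been measured, and the step of an at least 4.6-fold lower number from compound 1 to compound 2 (0.66 log units; beyond the scatter) at the carbonyl carbon gives no direction for it, so no change beyond the scatter is expected in this assay here. The estimated step is a 1.1-fold higher number from compound 2 to compound 3 (0.05 log units; within the scatter) and stays within that scatter. Compound 3 is expected at 12000 nM with a range from 4000 nM to 40000 nM in this estimate.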

Compound 3, half-maximal inhibitory concentration: > 50000 nM
Compound 3: a limit, no number (the forecaster's own chance of this, stated with the estimate: 20%); middle value at least 4.1-fold (0.61 log units) away from the limit.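

On the amide-type nitrogen, the group is not interchangeable in this assay: 1-(hydroxymethyl)-2-methylbutyl in place of the group of 9 heavy atoms gives an at least 4.6-fold higher number from compound 2 to compound 3 (0.66 log units; beyond the scatter). Compound 3 keeps the amide-type nitrogen on the carbonyl carbon, as compound 2 does, so that link alone does not carry the measurable number of compound 2. Compound 3 gives a limit and not a number, so its step from compound 1, itself a limit, cannot be read, and the series gathers at that limit: the limit of > 50000 nM in this assay, at which 2 of the 3 values shown sit.

Which part of the group leaving compound 2 accounts for its number stays open, as that group changes here only as a whole. On these data alone, how an amine such as 2-aminoethyl on the amide-type nitrogen would read in this assay also remains open.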